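The source may report more compounds than this note shows. Statements on the series, on what has been measured and on what is new or still open speak of the compounds shown alone.

Compound 1 `CCOC(=O)c1c(-c2cccc(OC)c2)[nH]c2cc(OC)ccc2c1=O`: in an ADME assay on Raji cells (Homo sapiens) for cytotoxicity, read by luminescence, with a stated time of 72 h (a higher number here means that more compound is needed for the effect, a lower number that less compound is needed), compound 1 gives > 21500 nM, which is a limit of the assay and not a number.
Compound 2 `CCOC(=O)c1c(-c2cccc(Cl)c2)[nH]c2cc(OC)ccc2c1=O`: in this assay compound 2 gives > 21500 nM, again a limit of the assay.
Compound 3 `CCOC(=O)c1c(-c2cccc(Br)c2)[nH]c2cc(OC)ccc2c1=O`: in this assay compound 3 gives > 21500 nM, also a limit of the assay.

Compound 1 therefore has no place on a scale of numbers in this assay; all that is known of it is a limit, and the three values of the series sit together at the limit of > 21500 nM in this assay, at which 3 of the 3 values shown sit. The steps within the series carry no readable size: a step that the two limits leave unreadable from compound 1 to compound 2, a step that the two limits leave unreadable from compound 1 to compound 3 and a step that the two limits leave unreadable from compound 2 to compound 3 all begin and end at the limit. None of them touches the methoxy group on the phenyl ring that is changed next.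

Compound 4 `CCOC(=O)c1c(-c2cccc(O)c2)[nH]c2cc(OC)ccc2c1=O` differs from compound 1 by hydrogen in place of methyl on an oxygen on an aromatic ring. Among the compounds with values here, no measured step bears on a methoxy to hydroxy change at this place, and the steps that exist are unreadable, so the expectation for compound 4 in this assay rests only on the three values at the limit. The step that the limit leaves unreadable from compound 1 to compound 4 is expected to show nothing beyond the scatter, with compound 4 most likely reported again as a limit. Compound 4 is estimated at 30000 nM, within a range of 10000 nM to 100000 nM.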

Compound 4, half-maximal effective concentration: > 21500 nM
Compound 4: only a limit was reported (the forecaster's own chance of this, stated with the estimate: 85%); the middle value does not contradict the limit.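

The steps linking compound 4 with compound 1, compound 2 and compound 3 cannot be read, since each compound is reported only as a limit of the assay: the limit of > 21500 nM in this assay, at which 4 of the 4 values shown sit.

The compounds shown leave open whether any change to the 3-methoxyphenyl group or the shared core would give a measurable number in this assay.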